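Bromo Added to the Core of Compound 1

The source may hold more compounds than are shown below. What is called first, only, known or untested is meant among the compounds shown, and "the series" means these compounds.

Compounds measured so far:
compound 1 `O=C(NNS(=O)(=O)c1ccccc1)c1cc2ccccc2[nH]1` with 36000 nM
compound 2 `O=C(NNS(=O)(=O)c1ccccc1)c1cc2cc(Br)ccc2o1` with 2500 nM

In an assay on isolated protein for inhibition of branched-chain-amino-acid aminotransferase, cytosolic (Homo sapiens) (on this read-out higher numbers stand for weaker inhibition and lower numbers for stronger inhibition), compound 1 gives 36000 nM, the highest of the two numbers recorded. Its nearest neighbour, compound 2, gives 2500 nM, a lower number that lies beyond the usual scatter. Compound 2 does not differ from compound 1 in one place only, since it carries both a bromo group and a different core, so the two values cannot be read as a single step.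

Compound 3 `O=C(NNS(=O)(=O)c1ccccc1)c1cc2cc(Br)ccc2[nH]1` keeps the core of compound 1 and differs from it in one place: bromo in place of hydrogen on an aromatic carbon. Within the data shown here, no measured pair shows this change on its own. Among the measured compounds shown here, the only guide is compound 2, whose bromo-bearing structure gives 2500 nM, well under compound 1. On that basis the step of a 4.5-fold lower number from compound 1 to compound 3 (0.65 log units; beyond the scatter) is expected to go downward, to a lower number, by more than the scatter, though with wide uncertainty since the core of compound 2 also differs. Compound 3 is therefore estimated at 8000 nM, with a range from 2000 nM to 30000 nM.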

Compound 3, half-maximal inhibitory concentration: 15000 nM
The estimate for compound 3 lay 1.9-fold (0.27 log units) below the measured number, within the range that was stated.
By their numbers in this assay, from the lowest: compound 2; then compound 3; then compound 1.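

Taken alone on the core of compound 1, bromo in place of hydrogen on this aromatic carbon, meta to a fused ring and para to a fused ring, gives a 2.4-fold lower number from compound 1 to compound 3 (0.38 log units; beyond the scatter) in this assay, a modest step that separates the two compounds. The bromo group by itself does not reach the level of the bromo-bearing compound with the other core: compound 3 stands at 15000 nM, while compound 2 stands lower at 2500 nM, and these two compounds differ in the core alone. Nothing available explains why this change lowers the number.

The compounds shown leave open how far a chloro group, a methoxy group or an amine on the same aromatic carbon would shift the number, and whether a carboxylic acid there would reverse the direction of the step. They also leave open whether bromo in place of hydrogen gives a similar step on the core of compound 2, since that core appears here only with the bromo group.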